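The source may hold more compounds than are shown below. What is called first, only, known or untested is meant among the compounds shown, and "the series" means these compounds.

Two compounds of the series have numbers in a functional assay on MKN-45 cells (Homo sapiens) for cytotoxicity, read by MTT assay, with a stated time of 72 h; a lower number here means a stronger inhibitor, a higher number a weaker inhibitor. Compound 1 `CN(C)CCCNc1nc(-c2ccc(NC(=O)Nc3ccccc3F)cc2)nc2ccsc12` gives 730 nM in this assay. Compound 2 `CN(C)CCCNc1nc(-c2ccc(NC(=O)Nc3ccc(F)cc3)cc2)nc2c(Cl)c(Cl)sc12` gives 1120 nM in this assay, and the two numbers lie within the scatter of each other, so neither compound can be set apart. Compound 3 `CN(C)CCCNc1nc(-c2ccc(NC(=O)Nc3ccc(Cl)cc3Cl)cc2)nc2c(Cl)c(Cl)sc12` is not yet measured; it differs from compound 2 by 2,4-dichlorophenyl in place of 4-fluorophenyl on an amide-type nitrogen. Among the measured compounds shown here, no measured pair shows this change, so nothing here sets its size; a step beyond the scatter in either direction is not expected. Compound 3 is expected to give about 900 nM in this assay, between 350 nM and 2500 nM. The expected step is a 1.2-fold lower number from compound 2 to compound 3 (0.09 log units; within the scatter).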

Compound 3, half-maximal inhibitory concentration: 2560 nM
The estimate for compound 3 lay 2.8-fold (0.45 log units) below the measured number, and the stated range ends below it.
By their numbers in this assay, from the lowest: compounds 1 and 2 (each within the scatter of the next); then compound 3.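

On the core of compound 2, the aryl group on the amide-type nitrogen is not a silent position in this assay: 2,4-dichlorophenyl in place of 4-fluorophenyl gives a 2.3-fold higher number from compound 2 to compound 3 (0.36 log units; beyond the scatter), a modest loss of inhibition. Among the compounds shown here, this is the first single-place step, and it runs towards a weaker inhibitor. Nothing measured here bears on the reason for this step.

As far as these compounds go, whether both chlorines are needed for the step stays open, and a 4-chlorophenyl group on the same nitrogen would separate them. Also open, from the compounds shown here alone, is whether a 4-methoxyphenyl group there would read any differently from 4-fluorophenyl.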